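The source may report more compounds than this note shows. Statements on the series, on what has been measured and on what is new or still open speak of the compounds shown alone.

Measured compounds:
Compound 1 `COc1ccc(-c2nc(SCC(=O)c3sc(-c4ccccc4)nc3C)[nH]c(=O)c2C#N)cc1`: 52.1%
Compound 2 `Cc1nc(-c2ccccc2)sc1C(=O)CSc1nc(-c2ccc(Cl)c(Cl)c2)c(C#N)c(=O)[nH]1`: 75.3%

In a functional assay on U-87MG ATCC cells for antiproliferative activity against U-87 MG (Homo sapiens), read by MTT assay, with a stated time of 48 h, tested at 50 uM (a lower number here means a stronger effect, a higher number a weaker effect of the compound at the concentration tested), compound 1 gives 52.1%, while compound 2 gives 75.3%. For the measured compounds named here, of the two numbers known so far, compound 2 stands at the higher one, and the single measured step, a number 23.2 percentage points higher from compound 1 to compound 2 (beyond the scatter), lies beyond the scatter. That step exchanged a 4-methoxyphenyl for a 3,4-dichlorophenyl and weakened the effect.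

Compound 3 `COc1ccc(-c2nc(SCC(=O)c3sc(-c4ccccc4)nc3C)[nH]c(=O)c2C#N)cc1OC` has not yet been measured. It differs from compound 2 in one place: 3,4-dimethoxyphenyl in place of 3,4-dichlorophenyl on an aromatic carbon. The step from compound 1 to compound 2 is the only one that bears on this change, and it runs in the opposite sense, since compound 3 again carries methoxy groups on that phenyl, now two of them, where compound 2 carries chlorines. Compound 3 is therefore expected to fall back toward the number of compound 1, a downward step of about a number 18.3 percentage points lower from compound 2 to compound 3 (beyond the scatter), with its size uncertain since the 3,4-dimethoxyphenyl itself has not been measured. For compound 3 the estimate is 57%, expected to lie between 40% and 76%.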

Compound 3, a percentage reported as activity, at one concentration (the size of the read-out at that concentration, not a potency): 21.4%
For compound 3 the middle estimate is 35.6 percentage points above the measured one; measured number outside the range, below it.
By their numbers in this assay, from the lowest: compound 3; then compound 1; then compound 2.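

In this assay, the step of a number 53.9 percentage points lower from compound 2 to compound 3 (beyond the scatter) shows that this aryl position can carry far more of the effect than the earlier pair revealed, and compound 3 gives the strongest effect of the three, with its steps to both others beyond the scatter. For the compounds shown here, the step of a number 30.7 percentage points lower from compound 1 to compound 3 (beyond the scatter) adds what the earlier compounds could not show: methoxy in place of hydrogen on that phenyl, a single change that keeps the first methoxy, is enough to move the read-out well beyond the scatter, so the number falls from the 3,4-dichlorophenyl through the 4-methoxyphenyl to the 3,4-dimethoxyphenyl, a trend that rests on these three compounds alone and that none of them goes against. Nothing available here accounts for this shift.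

Going by these compounds, what remains open is whether the stronger effect needs both methoxy groups or would also appear with an unsubstituted phenyl, a hydroxy group or an amine on that ring. These numbers also come from a single concentration, so they leave open how the compounds would rank in potency.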